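A few compounds are considered here, and "the series" means these few. Any claim that something is new, unique, unknown or untested is made for them only; others in the source may bear on it.

Working notes on the series. Compound 1 `O=C(/C=C\c1cccc(F)c1)N1N=C(c2ccncc2)OC1c1c[nH]c2ccccc12` carries a 3-fluorophenyl group on the chain. In an ADME assay on A549 cells (Homo sapiens) for cytotoxicity, read by MTT assay, with a stated time of 48 h (on this read-out lower numbers stand for stronger inhibition of growth and higher numbers for weaker inhibition of growth), compound 1 gives > 30 ug/mL, which is a limit of the assay and not a number. Compound 2 `O=C(/C=C\c1ccc(F)cc1)N1N=C(c2ccncc2)OC1c1c[nH]c2ccccc12` differs from it only in that ring. In this assay compound 2 gives > 30 ug/mL, again a limit rather than a number. The step that the two limits leave unreadable from compound 1 to compound 2 therefore cannot be read. Compound 2 thus stands at the limit of > 30 ug/mL in this assay, at which 2 of the 2 values shown sit, with no number of its own. Compound 3 `O=C(/C=C\c1cccc(Cl)c1)N1N=C(c2ccncc2)OC1c1c[nH]c2ccccc12` is the next member; the change from compound 2 is 3-chlorophenyl in place of 4-fluorophenyl on a double-bonded chain carbon bound to a double-bonded chain carbon. Going by the values given here, only the step from compound 1 to compound 2 touches the same place, and it is unreadable. No movement beyond the scatter is expected; because both measured compounds sit at the limit of > 30 ug/mL in this assay, at which 2 of the 2 values shown sit, compound 3 is expected mostly to return a limit as well. The expected step that the limit leaves unreadable from compound 2 to compound 3 is accordingly flat. For compound 3 the estimate in this assay is 40 ug/mL, within 15 ug/mL to 100 ug/mL.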

Compound 3, concentration for 50% growth inhibition: > 30 ug/mL
Compound 3 gave a limit, no number; the forecaster's own chance of this, stated with the estimate: 70%; the middle value does not contradict the limit.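

Going by these compounds alone, no step among compound 1, compound 2 and compound 3 can be read in this assay because each value is a limit and not a number: the limit of > 30 ug/mL in this assay, at which 3 of the 3 values shown sit. The compounds shown leave open whether 3-fluorophenyl, 4-fluorophenyl and 3-chlorophenyl differ at all in growth inhibition.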